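Propyl on the urea nitrogen: cytotoxicity outlook for compound 3

This account rests on a few compounds, and the source may have more. Where it says the series, first, only, none or still open, it means among the compounds named here.

Compound 1 `CS(=O)(=O)N(CCCCCCN1C[C@H](O)[C@@H](O)[C@H](O)[C@H]1CO)C1CCCCC1` carries a methylsulfonyl on the amine nitrogen. In an ADME assay on MDBK cells (Bos taurus) for cytotoxicity, read by MTT assay (a higher number here means that more compound is tolerated, a lower number that less compound is tolerated), compound 1 reaches only the assay limit, giving > 500000 nM. Compound 2 `NC(=O)N(CCCCCCN1C[C@H](O)[C@@H](O)[C@H](O)[C@H]1CO)C1CCCCC1` has carbamoyl in place of methylsulfonyl there. In this assay compound 2 likewise stops at the assay limit and gives > 500000 nM. Among the compounds with values here, the one measured step, a step that the two limits leave unreadable from compound 1 to compound 2, cannot be sized since both values sit at the limit of > 500000 nM in this assay, at which 2 of the 2 values shown sit. Compound 3 `CCCNC(=O)N(CCCCCCN1C[C@H](O)[C@@H](O)[C@H](O)[C@H]1CO)C1CCCCC1` differs from compound 2 by propyl in place of hydrogen on an amide-type nitrogen. No readable step bears on this change. Compound 3 is expected to remain at the limit, an estimated 500000 nM within 200000 nM to 1000000 nM, meaning an expected step of a number no higher from compound 2 to compound 3 (the limit leaves the size open) of no readable size.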

Compound 3, half-maximal cytotoxic concentration: > 500000 nM
Compound 3 was reported as a limit; the forecaster's own chance of this, stated with the estimate: 75%; the middle value sits exactly at the limit.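

Within the data shown here, compound 1, compound 2 and compound 3 all give limits in this assay, and no step among them can be read. The compounds shown leave open how the three differ in tolerated concentration, if they differ at all.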